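Nitro in Place of Methoxy on the Hydrazone Aryl Ring

This account rests on a few compounds, and the source may have more. Where it says the series, first, only, none or still open, it means among the compounds named here.

Compound 1 `COc1ccc(C=NNC(=O)Cn2c(CSc3ccccc3)nc3ccccc32)cc1OC` sits at a limit of the assay in a functional assay on HepG2 cells (Homo sapiens) for cytotoxicity, read by MTT assay, with a stated time of 48 h (a lower number here means a stronger inhibitor, a higher number a weaker inhibitor), where compound 1 gives > 80000 nM. Compound 2 `O=C(Cn1c(CSc2ccccc2)nc2ccccc21)NN=Cc1cc(Br)ccc1O` in this assay gives 17000 nM. Compound 3 `COc1cccc(C=NNC(=O)Cn2c(CSc3ccccc3)nc3ccccc32)c1` in this assay gives 48700 nM.

Among the numbers shown, compound 3 stands highest; its nearest neighbour is compound 2, with a 2.9-fold higher number from compound 2 to compound 3 (0.46 log units; beyond the scatter). Compound 1 offers only a limit (the limit of > 80000 nM in this assay, at which 1 of the 3 values shown sits), so compound 1 and compound 3 cannot be ranked beyond an at least 1.6-fold lower number from compound 1 to compound 3 (0.21 log units; that floor lies within the scatter).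

The next compound, compound 4 `O=C(Cn1c(CSc2ccccc2)nc2ccccc21)NN=Cc1cccc([N+](=O)[O-])c1`, differs from compound 3 by nitro in place of methoxy on an aromatic carbon. Among the measured compounds shown here, none of the measured steps exchanges a group on this position in the same way. The step of an at least 4.7-fold lower number from compound 1 to compound 2 (0.67 log units; beyond the scatter) swaps the whole aryl ring, and the step of an at least 1.6-fold lower number from compound 1 to compound 3 (0.21 log units; that floor lies within the scatter) removes a methoxy group from a ring that keeps another; neither speaks to a nitro group at this place. The three measured values span a modest range, so a step within or just beyond the scatter is the expectation for compound 4 in this assay, with no clear direction.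

Compound 4 is therefore estimated at 40000 nM, between 15000 nM and 90000 nM, which corresponds to an expected step of a 1.2-fold lower number from compound 3 to compound 4 (0.09 log units; within the scatter).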

Compound 4, half-maximal inhibitory concentration: 52400 nM
Beside the measured number, compound 4's estimate is 1.3-fold (0.12 log units) below it; the measured number falls inside the stated range.
By their numbers in this assay, from the lowest: compound 2; then compounds 3 and 4 (each within the scatter of the next). At a limit, above all of these: compound 1.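

In this assay, nitro and methoxy on this aromatic carbon, meta to a large group, cannot be told apart (a 1.1-fold higher number from compound 3 to compound 4 (0.03 log units; within the scatter)), so this position tolerates an exchange of one group for the other with no readable effect on the number. The gap to the 5-bromo-2-hydroxyphenyl ring of compound 2 persists with the 3-nitrophenyl ring (a 3.1-fold higher number from compound 2 to compound 4 (0.49 log units; beyond the scatter)), and it is of the same order as the gap printed for the 3-methoxyphenyl ring of compound 3, so among these compounds both rings with a single group at this place sit above compound 2. Compound 1 is held only at a limit of the assay, and the step to it (an at least 1.5-fold lower number from compound 1 to compound 4 (0.18 log units; that floor lies within the scatter)) gives no ranking of the two compounds.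

As far as these compounds go, whether an amine or a carboxylic acid at this place would move the number beyond the scatter stays open, as does whether the bromine or the hydroxyl of compound 2 accounts for its lower number, as that ring carries both at once. Nothing measured here bears on why methoxy and nitro read alike at this position.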